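A few compounds are considered here, and "the series" means these few. Any claim that something is new, unique, unknown or untested is made for them only; others in the source may bear on it.

Compound 1 `Nc1ncnc2c1c(-c1cnc3[nH]ccc3c1)nn2CCCC(=O)NO`: in a functional assay on HeLa cells (Homo sapiens) for inhibition, read by MTT assay, with a stated time of 72 h (a lower number here means a stronger inhibitor, a higher number a weaker inhibitor), compound 1 gives "not determined" (no result reported).
Compound 2 `Nc1ncnc2c1c(-c1cnc3[nH]ccc3c1)nn2CCCCCC(=O)NO`: in this assay compound 2 gives > 150000 nM, which is a limit of the assay and not a number.
Compound 3 `Nc1ncnc2c1c(-c1cnc3[nH]ccc3c1)nn2CCCCCCCCC(=O)NO`: in this assay compound 3 gives 7470 nM.

Within the data shown here, compound 3 therefore holds the only number in this assay; the other two entries are a limit and a missing result. Among the measured compounds shown here, the step of an at least 20-fold lower number from compound 2 to compound 3 (1.30 log units; beyond the scatter) is the only measured step, and it changes chain length, not the hydroxycarbamoyl group itself. Compound 4 `CNC(=O)CCCCCCCn1nc(-c2cnc3[nH]ccc3c2)c2c(N)ncnc21` differs from compound 3 by methylcarbamoyl in place of (hydroxycarbamoyl)methyl on a saturated chain carbon, seven bonds along the chain from an aromatic nitrogen. For the measured compounds named here, no measured step tests this change, so the expectation rests on the hydroxycarbamoyl group being present in every compound that gave a result. The step of a 13-fold higher number from compound 3 to compound 4 (1.13 log units; beyond the scatter) is expected to be a weakening beyond the scatter. Compound 4 is estimated at 100000 nM, between 20000 nM and 300000 nM.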

Compound 4, half-maximal inhibitory concentration: 29100 nM
Estimate against measurement, compound 4: 3.4-fold (0.54 log units) above, and the stated range covers the measured number.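

Changing the end of the chain rather than its length gives a 3.9-fold higher number from compound 3 to compound 4 (0.59 log units; beyond the scatter) in this assay. The hydroxycarbamoyl group therefore counts at this position, yet compound 4 shows that a number can be reached without it. The other step, an at least 5.1-fold lower number from compound 2 to compound 4 (0.71 log units; beyond the scatter), rests on a limit of the assay and not a number, so it gives only a minimum size: the limit of > 150000 nM in this assay, at which 1 of the 4 values shown sits.

Going by these compounds, how a carboxylic acid at the chain end would compare remains open. So does whether a longer chain would lower the number further, with either end group.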